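Hydroxy-nitrophenyl swap on the ene-sulfanyl ketone series

This account rests on a few compounds, and the source may have more. Where it says the series, first, only, none or still open, it means among the compounds named here.

Measured compounds:
Compound 1 `O=C(/C(=C\c1ccc([N+](=O)[O-])c(O)c1)SCc1ccc(Br)cc1)c1c(F)c(F)c(F)c(F)c1F` gives 10000 nM in a functional assay on DU-145 cells (Homo sapiens) for inhibition, read by trypan blue exclusion, with a stated time of 96 h; on this read-out lower numbers stand for stronger inhibition of growth and higher numbers for weaker inhibition of growth.
Compound 2 `O=C(/C(=C\c1ccc([N+](=O)[O-])c(O)c1)SCc1ccc(Br)cc1)c1ccc([N+](=O)[O-])c(Cl)c1` gives 1000 nM in this assay.
Compound 3 `O=C(/C(=C\c1ccc(O)c([N+](=O)[O-])c1)SCc1ccc(Br)cc1)c1ccc(C(F)(F)F)cc1` gives 10000 nM in this assay.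

Compound 3 stands level with compound 1 at the digits shown, and together these two are the highest of the three numbers; compound 2 sits apart with a lower number. Going by the values given here, the one step measured in a single place is a 10-fold lower number from compound 1 to compound 2 (1.00 log units; beyond the scatter), a change on the carbonyl carbon. Among the compounds with values here, compound 2 and compound 3 differ in two places at once, so their values show only that compound 3 sits higher.

Compound 4 `O=C(/C(=C\c1ccc([N+](=O)[O-])c(O)c1)SCc1ccc(Br)cc1)c1ccc(C(F)(F)F)cc1` differs from compound 3 as follows: 3-hydroxy-4-nitrophenyl in place of 4-hydroxy-3-nitrophenyl on a double-bonded chain carbon bound to a double-bonded chain carbon. Within the data shown here, no measured pair differs in this place alone, so no step bears directly on the change. Among the measured compounds shown here, compound 4 carries the same 3-hydroxy-4-nitrophenyl as compound 1 and compound 2, and the same trifluoromethylphenyl on the carbonyl carbon as compound 3, but no pair here isolates either comparison. With nothing to argue for a shift, a step within the scatter is expected, no change at the digits printed from compound 3 to compound 4 (within the scatter). Compound 4 is therefore estimated at 10000 nM in this assay, between 3000 nM and 30000 nM.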

Compound 4, concentration for 50% growth inhibition: 1000 nM
For compound 4 the middle estimate is 10-fold (1.00 log units) above the measured one; measured number below the stated range.
By their numbers in this assay, from the lowest: compounds 2 and 4 (each within the scatter of the next); then compounds 1 and 3 (each within the scatter of the next).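

With the 4-(trifluoromethyl)phenyl on the carbonyl carbon held fixed, this assay gives a 10-fold lower number from compound 3 to compound 4 (1.00 log units; beyond the scatter) for 3-hydroxy-4-nitrophenyl in place of 4-hydroxy-3-nitrophenyl, the first direct sign that the arrangement of hydroxy and nitro on this ring can alter growth inhibition in this series. The carbonyl side can now be read with the 3-hydroxy-4-nitrophenyl held constant: 4-(trifluoromethyl)phenyl in place of 3-chloro-4-nitrophenyl gives no change at the digits printed from compound 2 to compound 4 (within the scatter), while 4-(trifluoromethyl)phenyl in place of 2,3,4,5,6-pentafluorophenyl gives a 10-fold lower number from compound 1 to compound 4 (1.00 log units; beyond the scatter), so among these three carbonyl substituents only the pentafluorophenyl stands apart. Nothing on hand offers an explanation for either shift.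

Going by these compounds alone, whether the hydroxy and nitro arrangement has a similar effect with 3-chloro-4-nitrophenyl or 2,3,4,5,6-pentafluorophenyl on the carbonyl carbon remains open, as the single pair here rests on the 4-(trifluoromethyl)phenyl alone. Also open, on these data alone, is how the series responds when an amine or a carboxylic acid takes the place of the nitro group on the 3-hydroxy-4-nitrophenyl ring.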